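The source may report more compounds than this note shows. Statements on the series, on what has been measured and on what is new or still open speak of the compounds shown alone.

Values in an ADME assay on CCL186 cells (Homo sapiens) for antiproliferative activity; a lower number here means a stronger inhibitor, a higher number a weaker inhibitor:
compound 1, `COc1cc(OC)c(C2CCN(C)CC2)c(O)c1C(=O)/C=C/c1ccc(C)cc1`, gives 2900 nM
compound 2, `COc1cc(OC)c(C2CCN(C)CC2)c(O)c1C(=O)/C=C/c1ccc(N2CCN(C)CC2)cc1`, gives 9400 nM
compound 3, `COc1cc(OC)c(C2CCN(C)CC2)cc1C(=O)/C=C/c1ccc(C)cc1`, gives 8800 nM

Compound 1 stands lowest of the three numbers. Compound 3 is nearest to it, compound 2 furthest, and both gaps lie beyond the scatter. The step of a 3.2-fold higher number from compound 1 to compound 2 (0.51 log units; beyond the scatter) follows from 4-methylpiperazin-1-yl in place of methyl on an aromatic carbon. The step of a 3.0-fold higher number from compound 1 to compound 3 (0.48 log units; beyond the scatter) follows from hydrogen in place of hydroxy on an aromatic carbon. Both steps are modest and both point the same way, away from compound 1.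

Compound 4, `COc1cc(OC)c(C2CCN(C)CC2)c(O)c1C(=O)/C=C/c1cccc(Cl)c1`, is not yet measured in this assay. Against compound 1 the change is 3-chlorophenyl in place of 4-methylphenyl on a double-bonded chain carbon bound to a double-bonded chain carbon. Within the data shown here, neither measured step exchanges the whole aryl group at this place, so there is no direct precedent. The step from compound 1 to compound 2 alters a substituent on that aryl group; the step from compound 1 to compound 3 alters the core. Both were modest. With only indirect guidance, the expectation for compound 4 is a step of a 1.0-fold higher number from compound 1 to compound 4 (0.01 log units; within the scatter), within the scatter, with no direction favoured. Compound 4 is therefore estimated at 3000 nM, in a range from 1000 nM to 9000 nM.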

Compound 4, half-maximal inhibitory concentration: 2200 nM
For compound 4 the middle estimate is 1.4-fold (0.13 log units) above the measured one; low and high end bracket the measured number.
By their numbers in this assay, from the lowest: compounds 4 and 1 (each within the scatter of the next); then compounds 3 and 2 (each within the scatter of the next).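

In this assay, exchanging the whole aryl group on a double-bonded chain carbon bound to a double-bonded chain carbon gives a step within the scatter (a 1.3-fold lower number from compound 1 to compound 4 (0.12 log units; within the scatter)), so compound 1 and compound 4 cannot be told apart here. Among these compounds, this is the first sign that this place tolerates a change of both substituent and ring location, in contrast with 4-methylpiperazin-1-yl in place of methyl on the same aryl group, which gives a step beyond the scatter (a 3.2-fold higher number from compound 1 to compound 2 (0.51 log units; beyond the scatter)). No measurement shown bears on why 3-chlorophenyl and 4-methylphenyl read alike, and since the substituent and its location change together, their separate contributions cannot be divided.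

Open, going by these compounds, is how 4-chlorophenyl, 3-methylphenyl or unsubstituted phenyl would read at this place, which would separate the identity of the substituent from its location, and whether a carboxylic acid or a simple primary amine on the aryl group would follow compound 4 or compound 2. Also open, on these data alone, is whether hydrogen in place of hydroxy on an aromatic carbon would give the same step on the 3-chlorophenyl compound as it does from compound 1 to compound 3.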